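From methoxy to hydroxy on compound 1

The source may report more compounds than this note shows. Statements on the series, on what has been measured and on what is new or still open speak of the compounds shown alone.

Values measured in an ADME assay on MT4 cells (Homo sapiens) for cytotoxicity, read by spectrophotometry, with a stated time of 5 days (on this read-out lower numbers stand for higher toxicity in this test and higher numbers for lower toxicity in this test), are as follows
Compound 1 `CCn1cc(C(=O)O)c(=O)c2cc(F)c(N3CCN(CN4C(=O)/C(=N\NC(=S)NOC)c5cc(Cl)ccc54)CC3)cc21` gives 193000 nM
Compound 2 `CCn1cc(C(=O)O)c(=O)c2cc(F)c(N3CCN(CN4C(=O)/C(=N\NC(=S)NOC)c5cc(C)ccc54)CC3)cc21` gives 238000 nM
Compound 3 `CCn1cc(C(=O)O)c(=O)c2cc(F)c(N3CCN(CN4C(=O)/C(=N\NC(=S)NOC)c5cc(F)ccc54)CC3)cc21` gives 144000 nM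

In this assay compound 1 gives 193000 nM and sits within the scatter of both neighbours, with steps of (a 1.2-fold higher number from compound 1 to compound 2 (0.09 log units; within the scatter)) and (a 1.3-fold lower number from compound 1 to compound 3 (0.13 log units; within the scatter)). The remaining step (a 1.7-fold lower number from compound 2 to compound 3 (0.22 log units; within the scatter)) is also within the scatter, so these three compounds cannot be ranked.

Compound 4 `CCn1cc(C(=O)O)c(=O)c2cc(F)c(N3CCN(CN4C(=O)/C(=N\NC(=S)NO)c5cc(Cl)ccc54)CC3)cc21` has not yet been measured. It differs from compound 1 by one change (hydrogen in place of methyl on an oxygen), hydrogen in place of methyl on an oxygen, or methoxy to hydroxy. Among the measured compounds shown here, none of the measured steps makes this change. All three swap chloro, methyl and fluoro on an aromatic carbon, so they bear on it only indirectly, showing how little these three compounds differ. The data hold no direct comparison of methoxy and hydroxy, so the range is kept wide. With compound 1 at 193000 nM as the anchor, no step beyond the scatter is expected, and only a slight drift to a lower number is allowed for. The expected step is small (a 1.3-fold lower number from compound 1 to compound 4 (0.11 log units; within the scatter)). For compound 4 the estimated value is 150000 nM with an expected range from 70000 nM to 280000 nM in this read-out.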

Compound 4, half-maximal cytotoxic concentration: 186000 nM
Compound 4: the middle estimate sits 1.2-fold (0.09 log units) below what was measured; the range from low to high includes it.
By their numbers in this assay, from the lowest: compounds 3, 4, 1 and 2 (each within the scatter of the next).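

In this assay, among the compounds shown here, the new pair gives the first direct reading at this place, an oxygen on an amide-type nitrogen, with a 1.0-fold lower number from compound 1 to compound 4 (0.02 log units; within the scatter). The earlier compounds shown here varied only a group on an aromatic carbon, so they could not show that hydrogen in place of methyl on this oxygen leaves compound 4 within the scatter of compound 1. In this read-out, with chloro on the aromatic carbon, methoxyamino and hydroxyamino therefore cannot be told apart, and all four compounds shown remain unranked. Nothing in the available evidence bears on this result or accounts for it.

Going by these compounds, the hydroxyamino group appears here only with chloro on the aromatic carbon, so it remains open whether the same holds with methyl or fluoro there. Also open, on these data alone, is how this assay would respond to an ethyl group, a longer alkyl chain or a benzyl group on this oxygen, or to an amine or a carboxylic acid carried on such a chain.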